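Moving from (oxetan-3-yl)methyl to 3-methyloxetan-3-yl: working notes

The source may report more compounds than this note shows. Statements on the series, on what has been measured and on what is new or still open speak of the compounds shown alone.

Measured so far in a physicochemical assay for solubility, using the shake flask method, in phosphate buffer, with a stated time of 24 h, at pH 7.4; on this read-out higher numbers stand for higher solubility and lower numbers for lower solubility

- compound 1 `CC(Sc1nc2nn(CC3COC3)cc2c(=O)n1-c1ccccc1)c1ccccc1` gives 77000 nM
- compound 2 `Cn1ncc2c(=O)n(-c3ccccc3)c(SCc3cccc(F)c3)nc21` gives only a limit of the assay, < 700 nM
- compound 3 `CC(Sc1nc2nn(C3COC3)cc2c(=O)n1-c1ccccc1)c1cccnc1` gives 189000 nM

Of the two numbers in hand, compound 1 stands lowest at 77000 nM in this assay on this read-out. The nearest neighbour is compound 3 at 189000 nM and the gap between them lies beyond the usual scatter. The value for compound 2 is a limit and not a number.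

The next step starts from compound 1. Compound 4 `CC(Sc1nc2nn(C3(C)COC3)cc2c(=O)n1-c1ccccc1)c1ccccc1` carries 3-methyloxetan-3-yl in place of (oxetan-3-yl)methyl on an aromatic nitrogen and the two have the same atoms, joined differently. For the measured compounds named here, no measured pair differs in one place only, so there is no direct precedent for the size of this step. The expectation therefore rests on compound 1 at 77000 nM and on the unchanged atom count, and no shift beyond the scatter is expected in this assay in either direction. The estimated step of a 1.1-fold lower number from compound 1 to compound 4 (0.04 log units; within the scatter) is correspondingly small. Compound 4 is expected at 70000 nM within an estimated range of 20000 nM to 200000 nM on this read-out.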

Compound 4, solubility: 19000 nM
Estimate against measurement, compound 4: 3.7-fold (0.57 log units) above, and the stated range ends above it.
By their numbers in this assay, from the lowest: compound 4; then compound 1; then compound 3. At a limit, below all of these: compound 2.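

In this assay, for the compounds shown here, 3-methyloxetan-3-yl in place of (oxetan-3-yl)methyl on an aromatic nitrogen gives a 4.1-fold lower number from compound 1 to compound 4 (0.61 log units; beyond the scatter), and this is the first step that differs in one place only. The two groups match in every count compared, with the same heavy atoms, the same four-membered ring with one hetero atom, the same donors and acceptors and no net charge, so the way these atoms are joined is the only difference left at this position, and a rearrangement of the same atoms here is enough for a step beyond the scatter. Nothing measured for these compounds bears on why the number falls at this position.

This single step leaves open whether the same change would give a step of similar size with the 3-pyridyl group of compound 3 in place of the phenyl on the sulfur-bearing side chain, since compound 3 differs from compound 4 in more than one place. It also leaves open how a basic amine such as azetidine, a carboxylic acid or a longer chain such as hydroxyethyl on the same aromatic nitrogen would compare with either oxetane group in this assay.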